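The compounds below may be only part of what the source reports. "The series", "measured", "known", "first", "only" and "open" are said of these compounds alone.

Measured compounds:
compound 1 `COc1ccc(C(=O)Nc2nccn3cc(-c4ccccc4)nc23)cc1` — 162 nM
compound 2 `O=C(Nc1nc(-c2ccccc2)cn2cc(-c3ccccc3)nc12)c1ccc(Cl)cc1` — 156 nM

Both compounds were tested in an assay on cells for displacement of a labelled ligand from transmembrane domain-containing protein TMIGD3 (Homo sapiens), read by scintillation counting, with a stated time of 120 min; a lower number here means a stronger inhibitor, a higher number a weaker inhibitor. Compound 1 gives 162 nM, and compound 2 gives 156 nM. The two numbers differ by less than the usual scatter of this assay, so neither compound can be called the stronger; compound 2 and compound 1 sit at the same level. Compound 3 `O=C(Nc1nc(-c2ccccc2)cn2cc(-c3ccccc3)nc12)c1cccnc1` has not yet been measured. It differs from compound 2 in one place: pyridin-3-yl in place of 4-chlorophenyl on a carbonyl carbon. Within the data shown here, no measured pair shows this kind of exchange, so there is no step to lean on. The expectation is a modest move toward a higher number, of a size that may not clear the scatter, which is expressed as a 1.9-fold higher number from compound 2 to compound 3 (0.28 log units; within the scatter). Compound 3 is therefore estimated at 300 nM in this assay, with a range from 100 nM to 900 nM.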

Compound 3, inhibition constant: 54 nM
For compound 3 the middle estimate is 5.6-fold (0.74 log units) above the measured one; the whole stated range lies above it.
By their numbers in this assay, from the lowest: compound 3; then compounds 2 and 1 (each within the scatter of the next).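

On a carbonyl carbon whose other neighbour is the amide-type nitrogen, pyridin-3-yl in place of 4-chlorophenyl gives, in this assay, a 2.9-fold lower number from compound 2 to compound 3 (0.46 log units; beyond the scatter), so the group held at this position can shift the result beyond the usual scatter. Compound 1 and compound 2 could not show this, since they differ in more than one place and sit at the same level. The entering ring holds one hydrogen-bond acceptor and the leaving ring none, but nothing available links that difference to the change in binding.

Going by these compounds, it remains open whether the ring nitrogen or the loss of chlorine accounts for the step, and how pyridin-4-yl or pyridin-2-yl would compare on the same carbonyl. Whether the exchange carries over to the core of compound 1 is also unresolved.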